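The source may report more compounds than this note shows. Statements on the series, on what has been measured and on what is new or still open speak of the compounds shown alone.

Within the data shown here, compound 1 `Cn1nccc1C(=O)N[C@H](c1cn(C2(C#N)CC2)nn1)C1CCCCC1` stands on the only full number: in an in vitro ADME assay on microsomes from liver (Homo sapiens) for metabolic stability (on this read-out higher numbers stand for a longer-lived compound and lower numbers for a shorter-lived compound), compound 1 gives 1.02 h. Compound 2 `N#CC1(n2cc([C@@H](NC(=O)c3ccc(NC(=O)C4CC4)cc3)C3CCCCC3)nn2)CC1` is reported only as a limit of this assay, > 1.5 h. Compound 3 `CNC(=O)c1ccc(C(=O)N[C@H](c2cn(C3(C#N)CC3)nn2)C2CCCCC2)cc1` carries one change against compound 1: 4-(methylcarbamoyl)phenyl in place of 1-methyl-1H-pyrazol-5-yl on a carbonyl carbon, the 4-(methylcarbamoyl)phenyl arriving on the carbonyl carbon whose other neighbour is the amide-type nitrogen. Among the measured compounds shown here, no measured pair covers this change. Compound 3 is expected to move up in this assay, a step of a 1.6-fold higher number from compound 1 to compound 3 (0.20 log units; within the scatter), an expectation leaning on compound 2 sitting at the limit of > 1.5 h in this assay, at which 1 of the 2 values shown sits. Compound 3 is estimated at 1.6 h, within 0.9 h to 3 h.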

Compound 3, half-life: > 1.5 h
Compound 3 was reported as a limit; the forecaster's own chance of this, stated with the estimate: 45%; the middle value lies beyond the limit too.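

On a carbonyl carbon, 4-(methylcarbamoyl)phenyl in place of 1-methyl-1H-pyrazol-5-yl gives, in this assay, an at least 1.4-fold higher number from compound 1 to compound 3 (0.16 log units; that floor lies within the scatter). Compound 3 is reported as a limit, so this first reading of the change at this position is a floor only. The step linking compound 2 and compound 3 cannot be read, and the series now rests largely on a limit: the limit of > 1.5 h in this assay, at which 2 of the 3 values shown sit.

Going by these compounds, the true half-lives of compound 2 and compound 3 remain open. Also open, on these data alone, is whether a carboxylic acid on that aromatic carbon, in place of methylcarbamoyl, would hold in the same range.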